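A Methyl on the Fused Core of Compound 3

The compounds below may be only part of what the source reports. "The series", "measured", "known", "first", "only" and "open" are said of these compounds alone.

Measured compounds:
compound 1, `CC(C)CSc1nnc2scc(-c3ccc(Cl)cc3)n12`, 256 nM
compound 2, `O=C(CSc1nnc2scc(-c3ccc(Br)cc3)n12)c1ccc(Br)cc1`, > 10000 nM
compound 3, `Brc1ccc(-c2csc3nccn23)cc1`, 380 nM

In an assay on cells for inhibition of Indoleamine 2,3-dioxygenase 1 (Homo sapiens) (on this read-out lower numbers stand for stronger inhibition and higher numbers for weaker inhibition), compound 1 gives 256 nM. Compound 2 reaches only a limit of the assay, > 10000 nM, so it yields no number; (the limit of > 10000 nM in this assay, at which 1 of the 3 values shown sits). Compound 3 gives 380 nM in this assay, a value that lies within the scatter of the number from compound 1, so no order between the two can be read.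

Compound 4, `Cc1sc2nccn2c1-c1ccc(Br)cc1`, has not yet been measured. It differs from compound 3 by methyl in place of hydrogen on an aromatic carbon. Among the compounds with values here, no measured pair shows what such a methyl does on this core, so the step of a 1.2-fold lower number from compound 3 to compound 4 (0.07 log units; within the scatter) is expected to stay within the scatter. Compound 4 is therefore estimated at 320 nM, between 110 nM and 1000 nM.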

Compound 4, half-maximal inhibitory concentration: 3110 nM
The estimate for compound 4 lay 9.7-fold (0.99 log units) below the measured number; the whole stated range lies below it.
By their numbers in this assay, from the lowest: compounds 1 and 3 (each within the scatter of the next); then compound 4. At a limit, above all of these: compound 2.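

On the core of compound 3, this position proves sensitive: methyl in place of hydrogen on the aromatic carbon next to the ring sulfur gives an 8.2-fold higher number from compound 3 to compound 4 (0.91 log units; beyond the scatter) in this assay. Within the data shown here, this single added carbon is enough to weaken inhibition, which no earlier pair could show. Nothing measured here accounts for the step. As far as these compounds go, whether any other group on this carbon would behave the same way remains open. A fluorine, a hydroxyl or an ethyl in place of the methyl would show whether the step belongs to methyl alone.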